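From 3-hydroxyphenyl to 4-hydroxyphenyl on a shared core

A few compounds are considered here, and "the series" means these few. Any claim that something is new, unique, unknown or untested is made for them only; others in the source may bear on it.

Measured in a functional assay on MGC-803 cells (Homo sapiens) for inhibition, read by MTT assay, with a stated time of 72 h; on this read-out lower numbers stand for stronger inhibition and higher numbers for weaker inhibition:
- compound 1 `C#CCSc1nc(Nc2ccccc2Cl)c2ccncc2n1`: 27600 nM
- compound 2 `C#CCSc1nc(Nc2ccc(Cl)cc2)c2ccncc2n1`: 16400 nM
- compound 3 `C#CCSc1nc(Nc2cccc(O)c2)c2ccncc2n1`: 15700 nM

The three values sit close together: a 1.8-fold lower number from compound 1 to compound 3 (0.25 log units; within the scatter) and a 1.0-fold lower number from compound 2 to compound 3 (0.02 log units; within the scatter) both lie within the scatter. Compound 3 therefore has no clear rank among them. Compound 4 `C#CCSc1nc(Nc2ccc(O)cc2)c2ccncc2n1` keeps the shared core and has 4-hydroxyphenyl in place of 3-hydroxyphenyl on a nitrogen on an aromatic ring. Among the measured compounds shown here, no measured step covers this exact swap. The nearest guide is a 1.7-fold lower number from compound 1 to compound 2 (0.23 log units; within the scatter), with 4-chlorophenyl in place of 2-chlorophenyl, and it too lies within the scatter. No shift beyond the scatter is therefore expected in this assay, and the estimated change is a 1.0-fold lower number from compound 3 to compound 4 (0.02 log units; within the scatter). Compound 4 is expected at 15000 nM, with an estimated range of 7500 nM to 30000 nM.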

Compound 4, half-maximal inhibitory concentration: > 80000 nM
Compound 4 ended at the assay's limit; the forecaster's own chance of this, stated with the estimate: 8%; middle value at least 5.3-fold (0.72 log units) from the limit.
By their numbers in this assay, from the lowest: compounds 3, 2 and 1 (each within the scatter of the next). At a limit, above all of these: compound 4.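

The value of compound 4 is a limit of the assay and not a number: the limit of > 80000 nM in this assay, at which 1 of the 4 values shown sits. In this assay, among the compounds shown here, the same atoms joined differently produce the first change beyond the scatter, as 4-hydroxyphenyl replaces 3-hydroxyphenyl: an at least 5.0-fold higher number from compound 3 to compound 4 (0.70 log units; beyond the scatter). Compound 4 also separates from both chlorophenyl compounds, with an at least 4.8-fold higher number from compound 2 to compound 4 (0.68 log units; beyond the scatter) and an at least 2.8-fold higher number from compound 1 to compound 4 (0.46 log units; beyond the scatter).

The compounds shown leave open whether this loss is specific to hydroxy. 4-Aminophenyl or 4-methoxyphenyl in place of 4-hydroxyphenyl could show whether the numbers stay at this limit or return to those of compounds 1, 2 and 3.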